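A few compounds are considered here, and "the series" means these few. Any claim that something is new, unique, unknown or untested is made for them only; others in the source may bear on it.

In a functional assay on HOP-62 cells (Homo sapiens) for inhibition, read by sulforhodamine B assay, with a stated time of 48 h (a higher number here means that more compound is tolerated, a lower number that less compound is tolerated), compound 1 (`Cc1ccc(C2=NN(c3ccc(S(C)(=O)=O)cc3)C(=O)CC2)cc1`) gives > 100000 nM as a limit and not a number. Compound 2 (`Cc1cc(O)ccc1C1=NN(c2ccc(S(C)(=O)=O)cc2)C(=O)CC1`) gives > 100000 nM as a limit too. Compound 2 therefore stands only at the limit of > 100000 nM in this assay, at which 2 of the 2 values shown sit, and has no readable number. For the measured compounds named here, the one measured step that the two limits leave unreadable from compound 1 to compound 2 offers no size to carry forward. Compound 3 (`CCc1ccc(C2=NN(c3ccc(S(C)(=O)=O)cc3)C(=O)CC2)cc1`) follows through 4-ethylphenyl in place of 4-hydroxy-2-methylphenyl on a carbon with a double bond to nitrogen with 4-ethylphenyl in place of 4-hydroxy-2-methylphenyl. Compound 1 at > 100000 nM as a limit is the nearest guide, so no step beyond the scatter is expected. The expected step of a number no higher from compound 2 to compound 3 (the limit leaves the size open) is an estimate that probably ends at the limit again. Compound 3 is estimated at 100000 nM within 50000 nM to 200000 nM in this assay for now.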

Compound 3, concentration lethal to 50% of the cells: > 100000 nM
Compound 3: only a limit was reported (the forecaster's own chance of this, stated with the estimate: 85%); the middle value lies on the limit itself.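

The result for compound 3 is again a limit, so the steps among compound 1, compound 2 and compound 3 cannot be read: the limit of > 100000 nM in this assay, at which 3 of the 3 values shown sit.

The compounds shown leave open whether 4-methylphenyl, 4-hydroxy-2-methylphenyl and 4-ethylphenyl differ at all in this read-out.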